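Swapping a Phenoxy Group for a Piperidine in a Solubility Series

This account rests on a few compounds, and the source may have more. Where it says the series, first, only, none or still open, it means among the compounds named here.

Measured compounds:
- compound 1, `COc1ccc2[nH]c(C(=O)N3CC(=O)N(Cc4ccccc4)[C@@H](COc4ccccc4)C3)cc2c1`: 12200 nM
- compound 2, `COc1cccc(CN2C(=O)CN(C(=O)c3cc4cc(OC)ccc4[nH]3)C[C@@H]2CC2CCCCC2)c1`: 21400 nM
- compound 3, `COc1ccc2[nH]c(C(=O)N3CC(=O)N(Cc4ccccc4)[C@@H](N4CCC(Cc5ccccc5)CC4)C3)cc2c1`: 9300 nM

All three share one core and were run in a physicochemical assay for solubility, read by spectrophotometry, in phosphate buffer, with a stated time of 2 h, at pH 7.4; on this read-out higher numbers stand for higher solubility and lower numbers for lower solubility. Compound 1 gives the second highest of the three numbers. Its nearest neighbour is compound 3, whose number is lower but within the usual scatter of this assay, and its furthest is compound 2, whose number is higher yet also within that scatter. Taken together, the three values therefore do not separate from one another, and no compound can be called the most or least soluble.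

The unmeasured compound 4, `COc1ccc2[nH]c(C(=O)N3CC(=O)N(Cc4ccccc4)[C@@H](CN4CCC(C(C)C)CC4)C3)cc2c1`, differs from compound 1 in one place: 4-isopropylpiperidin-1-yl in place of phenoxy on a saturated chain carbon bound to a saturated ring carbon. Because compound 3, which also carries a piperidine ring on the core, gives 9300 nM, a value within the scatter of compound 1, the change is not expected to move the number far. The step of a 1.5-fold higher number from compound 1 to compound 4 (0.17 log units; within the scatter) is estimated to be small and, if anything, upward. For compound 4 in this assay a solubility of 18000 nM is expected, with a likely range from 6000 nM to 55000 nM.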

Compound 4, solubility: 12000 nM
For compound 4 the middle estimate is 1.5-fold (0.18 log units) above the measured one, within the range that was stated.
By their numbers in this assay, from the lowest: compounds 3, 4, 1 and 2 (each within the scatter of the next, the first and the last beyond it).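

Within the data shown here, compound 1 and compound 4 give the first comparison that differs in only one place, so the shared core and the rest of the molecule are held fixed. In this assay, putting 4-isopropylpiperidin-1-yl in place of phenoxy on a saturated chain carbon bound to a saturated ring carbon gives a 1.0-fold lower number from compound 1 to compound 4 (0.01 log units; within the scatter), so this exchange of a six-membered aromatic ring of carbon for a larger group with a six-membered non-aromatic ring leaves the two read-outs inseparable. This holds for this one pair, and nothing available explains the result.

The single exchange changes several things at once, so the compounds shown leave open whether the ring, its nitrogen or the isopropyl group matters on its own, a question that plain piperidin-1-yl or 4-isopropylphenoxy on the same carbon could help to separate. It also remains open whether the read-out would stay in the same region with a carboxylic acid or a primary amine at this place, since both groups shown here carry no net charge.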